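Methoxy to ethoxy on two related cores

A few compounds are considered here, and "the series" means these few. Any claim that something is new, unique, unknown or untested is made for them only; others in the source may bear on it.

Compound 1 `COc1ccc(-c2c(C(=O)c3cc(OC)c(OC)c(OC)c3)sc3ccccc23)cc1`: 1600 nM
Compound 2 `CCOc1ccc(-c2c(C(=O)c3cc(OC)c(OC)c(OC)c3)sc3ccccc23)cc1`: 4100 nM
Compound 3 `COc1ccc(Nc2c(C(=O)c3cc(OC)c(OC)c(OC)c3)sc3ccccc23)cc1`: 3500 nM

Of the compounds shown here, three have been tested in a functional assay on Jurkat cells (Homo sapiens) for antiproliferative activity, read by MTT assay, with a stated time of 72 h; a higher number here means a weaker inhibitor, a lower number a stronger inhibitor. Going from compound 1 to compound 2, the change is methyl in place of hydrogen on a saturated chain carbon bound to an oxygen on an aromatic ring, and it gave a 2.6-fold higher number from compound 1 to compound 2 (0.41 log units; beyond the scatter). Compound 3 differs from compound 1 in its core, the difference being ((4-methoxyphenyl)amino in place of 4-methoxyphenyl on an aromatic carbon), and this gave a 2.2-fold higher number from compound 1 to compound 3 (0.34 log units; beyond the scatter). Between compound 2 and compound 3 the numbers show a 1.2-fold lower number from compound 2 to compound 3 (0.07 log units; within the scatter).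

Compound 4 `CCOc1ccc(Nc2c(C(=O)c3cc(OC)c(OC)c(OC)c3)sc3ccccc23)cc1` has not yet been measured in this assay. It stands to compound 3 as compound 2 stands to compound 1: the change is methyl in place of hydrogen on a saturated chain carbon bound to an oxygen on an aromatic ring, and the place is described in the same words for both pairs, so it is the same change on a different core. Because the earlier step was a 2.6-fold higher number from compound 1 to compound 2 (0.41 log units; beyond the scatter), the step from compound 3 to compound 4 is expected to be similar, a 2.4-fold higher number from compound 3 to compound 4 (0.39 log units; beyond the scatter). Compound 4 is therefore estimated at 8500 nM, with a likely range from 3500 nM to 20000 nM.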

Compound 4, half-maximal inhibitory concentration: 300 nM
For compound 4 the middle estimate is 28-fold (1.45 log units) above the measured one; the measured number lies below the stated range.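

Methoxy to ethoxy did not carry from one core to the other in this assay. On the core of compound 3 it gave a 12-fold lower number from compound 3 to compound 4 (1.07 log units; beyond the scatter), the opposite direction to the step on the core of compound 1, and the two steps differ: the same change on two cores in this assay, a 2.6-fold higher number (0.41 log units; beyond the scatter) from compound 1 to compound 2 and a 12-fold lower number (1.07 log units; beyond the scatter) from compound 3 to compound 4, 30-fold (1.48 log units) apart, beyond the scatter of two such steps

With ethoxy held fixed, (4-ethoxyphenyl)amino in place of 4-ethoxyphenyl gave a 14-fold lower number from compound 2 to compound 4 (1.14 log units; beyond the scatter), and the step that combines both changes is a 5.3-fold lower number from compound 1 to compound 4 (0.73 log units; beyond the scatter). These are single pairs on two cores, so they show that the effect of this change depends on the core within these four compounds, but not why, nor whether it would hold for any other pair.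

The compounds shown leave open whether the reversal continues with a longer chain such as propoxy, or with a hydroxy or dimethylamino group in the same place. They also leave open whether an ether oxygen in place of the amine link would behave as the amine link does.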